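A few compounds are considered here, and "the series" means these few. Any claim that something is new, unique, unknown or untested is made for them only; others in the source may bear on it.

Two compounds have measured numbers in a functional assay on A2780 cells (Homo sapiens) for inhibition, read by sulforhodamine B assay; on this read-out higher numbers stand for weaker inhibition of growth and lower numbers for stronger inhibition of growth. Compound 1 (`Oc1cccc2[nH]c(-c3ccc(-c4ccc(-c5ccc(OC(F)(F)F)cc5)cc4)cc3)nc12`) gives 2900 nM, and compound 2 (`Cc1ccc2[nH]c(-c3ccc(-c4ccc(-c5ccc(F)cc5)cc4)cc3)nc2c1`) gives 24600 nM. Compound 2 therefore holds the higher of the two numbers, meaning the weaker inhibition of growth, and its gap to compound 1 lies beyond the scatter. Compound 3 (`Cc1ccc2[nH]c(-c3ccc(-c4ccc(-c5ccc(OC(F)(F)F)cc5)cc4)cc3)nc2c1`) keeps the whole of compound 2 except for one substituent: trifluoromethoxy stands in place of fluoro on an aromatic carbon, para to a large group (trifluoromethoxy in place of fluoro on an aromatic carbon).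

For the measured compounds named here, no measured pair isolates this change, as compound 1 and compound 2 differ in more than one place. Going by the values given here, the only guide is that compound 1, which carries the same 4-(trifluoromethoxy)phenyl group on a different core, gives 2900 nM. On that limited evidence, a moderate move towards a lower number is expected in this assay, with the estimated change being a 2.7-fold lower number from compound 2 to compound 3 (0.44 log units; beyond the scatter). Compound 3 is expected at about 9000 nM, with an estimated range of 3000 nM to 25000 nM.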

Compound 3, concentration for 50% growth inhibition: 12300 nM
Estimate against measurement, compound 3: 1.4-fold (0.14 log units) below; low and high end bracket the measured number.
By their numbers in this assay, from the lowest: compound 1; then compounds 3 and 2 (each within the scatter of the next).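

For the compounds shown here, replacing fluoro with trifluoromethoxy on an aromatic carbon, para to a large group, gives a 2.0-fold lower number from compound 2 to compound 3 (0.30 log units; within the scatter) in this assay, the first reading of this change with all else held fixed, and it cannot be told from the scatter. With the 4-(trifluoromethoxy)phenyl group held fixed, 5-methyl-1H-benzimidazol-2-yl in place of 4-hydroxy-1H-benzimidazol-2-yl gives a 4.2-fold higher number from compound 1 to compound 3 (0.63 log units; beyond the scatter), so on these compounds the change at the core is the one that reads beyond the scatter, while the change at this position does not. No measurement available here accounts for the size of either step.

On these data alone, it remains open whether fluoro and trifluoromethoxy would also read alike on the core of compound 1, and whether the hydroxy group itself or some other part of that core carries the step between the two cores. As far as these compounds go, it is equally open whether a group of another kind on this aromatic carbon, such as an amine or a carboxylic acid, would move the number beyond the scatter.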